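This account rests on a few compounds, and the source may have more. Where it says the series, first, only, none or still open, it means among the compounds named here.

Compound 1 `c1ccc(-c2cc(-c3ccsc3)cc(-c3ccccn3)n2)nc1`: 0.89 ug/mL
Compound 2 `c1ccc(-c2cc(-c3ccoc3)cc(-c3ccccn3)n2)nc1`: 0.33 ug/mL

Both values come from a functional assay on SK-MEL-2 cells (Homo sapiens) for antiproliferative activity; a higher number here means a weaker inhibitor of growth, a lower number a stronger inhibitor of growth. Compound 2 holds the lower of the two numbers, 0.33 ug/mL. For the measured compounds named here, the only measured step is a 2.7-fold lower number from compound 1 to compound 2 (0.43 log units; beyond the scatter), and it replaces thiophen-3-yl with furan-3-yl.

Compound 3 `c1ccc(-c2cc(-c3cccs3)cc(-c3ccccn3)n2)nc1` has not yet been measured. It keeps the core of compound 2 and changes one group: thiophen-2-yl in place of furan-3-yl on an aromatic carbon. Thiophen-2-yl stands in place of furan-3-yl on an aromatic carbon, opposite the ring nitrogen.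

Going by the values given here, the one measured step bears on this change only in part. Compound 1 carries thiophen-3-yl and gives 0.89 ug/mL, so it is the nearest guide, but its group is not the thiophen-2-yl of compound 3. Among the compounds with values here, no measurement yet compares those two groups. A modest step of similar size is therefore expected, in the opposite direction, towards a higher number. The expected change is a 2.4-fold higher number from compound 2 to compound 3 (0.38 log units; beyond the scatter). The estimate for compound 3 is 0.8 ug/mL, with an expected range from 0.3 ug/mL to 2.2 ug/mL.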

Compound 3, concentration for 50% growth inhibition: 1.8 ug/mL
For compound 3 the middle estimate is 2.3-fold (0.35 log units) below the measured one, within the range that was stated.
By their numbers in this assay, from the lowest: compound 2; then compound 1; then compound 3.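

In this assay, the position opposite the ring nitrogen responds to where a five-membered ring is attached, as well as to which hetero atom that ring holds: with sulfur kept, the move from thiophen-3-yl to thiophen-2-yl gives a 2.0-fold higher number from compound 1 to compound 3 (0.31 log units; beyond the scatter). The step of a 5.5-fold higher number from compound 2 to compound 3 (0.74 log units; beyond the scatter) changes the hetero atom and the attachment together, so on its own it cannot be divided between the two, although compound 1 stands between these compounds and shows that the change of attachment alone is beyond the scatter. Furan-3-yl and thiophen-2-yl are the same in heavy atom count, hydrogen-bond donors and acceptors, and charge, so those counts do not separate these compounds, and nothing at hand accounts for the difference.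

The compounds shown leave open how furan-2-yl would fall, which would show whether the preference between attachments holds with oxygen as it does with sulfur. They also leave open whether a five-membered aromatic ring is needed here at all, as against an amine or a longer chain, and what part the two pyridin-2-yl groups play, since both stay constant throughout.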